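Aryl variation on the shared core: compound 4 expected

The compounds below may be only part of what the source reports. "The series", "measured", "known", "first", "only" and "open" are said of these compounds alone.

Three compounds share the core of compound 1 `CCCS(=O)(=O)Nc1ccc(F)c(C(=O)c2n[nH]c3ncc(-c4ccccc4C)cc23)c1F` and differ only in the aryl group on the aromatic carbon. In an assay for binding affinity to dual specificity mitogen-activated protein kinase kinase 4 (Homo sapiens), read by KINOMEscan, tested at 100 nM (on this read-out higher numbers stand for a weaker effect at the one concentration tested and lower numbers for a stronger effect), compound 1 gives 7%, compound 2 `CCCS(=O)(=O)Nc1ccc(F)c(C(=O)c2n[nH]c3ncc(-c4ccc(OC)cc4)cc23)c1F` gives 4.2% and compound 3 `CCCS(=O)(=O)Nc1ccc(F)c(C(=O)c2n[nH]c3ncc(-c4cccc(N)c4)cc23)c1F` gives 1.6%. The steps of a number 2.8 percentage points lower from compound 1 to compound 2 (within the scatter), a number 5.4 percentage points lower from compound 1 to compound 3 (within the scatter) and a number 2.6 percentage points lower from compound 2 to compound 3 (within the scatter) all lie within the scatter, so compound 3 cannot be set apart from the other two. Compound 4 `CCCS(=O)(=O)Nc1ccc(F)c(C(=O)c2n[nH]c3ncc(-c4ccc(Cl)c(C(F)(F)F)c4)cc23)c1F` continues the aryl variation: 4-chloro-3-(trifluoromethyl)phenyl in place of 3-aminophenyl on an aromatic carbon. Among the measured compounds shown here, the three measured aryl exchanges are the steps that bear on this change, and none moved the read-out beyond the scatter, so no step beyond the scatter is expected in this assay. The expected step is a number 3.4 percentage points higher from compound 3 to compound 4 (within the scatter). For compound 4 the estimate is 5%, within 1% to 20%.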

Compound 4, a percentage reported as activity, at one concentration (the size of the read-out at that concentration, not a potency): 15%
The estimate for compound 4 lay 10 percentage points below the measured number; measured number inside the range.
By their numbers in this assay, from the lowest: compounds 3, 2, 1 and 4 (each within the scatter of the next, the first and the last beyond it).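

Among the compounds shown here, the aryl position is not indifferent in this assay: 4-chloro-3-(trifluoromethyl)phenyl gives the first steps beyond the scatter, both modest (a number 13.4 percentage points higher from compound 3 to compound 4 (beyond the scatter); a number 10.8 percentage points higher from compound 2 to compound 4 (beyond the scatter)). Against 2-methylphenyl the same exchange stays within the scatter (a number 8 percentage points higher from compound 1 to compound 4 (within the scatter)), so compound 4 separates from only two of the three earlier compounds.

On these data alone, whether 4-chlorophenyl or 3-(trifluoromethyl)phenyl alone would carry this step remains open. Nothing available explains the step.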